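The compounds below may be only part of what the source reports. "The series", "measured", "known", "first", "only" and "open" are said of these compounds alone.

Measured compounds:
- compound 1 `COc1ccc(-c2cc(/C=C/C(=O)c3ccc(N)cc3)[nH]n2)cc1` gives 94%
- compound 2 `COc1ccc(-c2cc(/C=C/C(=O)c3ccc(N)cc3)[nH]n2)cc1OC` gives 89%
- compound 3 `COc1cc(C(=O)/C=C/c2cc(-c3cc(OC)c(OC)c(OC)c3)n[nH]2)cc(OC)c1OC` gives 95%

These three were tested in a functional assay on MCF7 cells (Homo sapiens) for cytotoxicity, read by sulforhodamine B assay, with a stated time of 48 h, tested at 0.1 uM; on this read-out higher numbers stand for a weaker effect at the one concentration tested and lower numbers for a stronger effect. Compound 2 and compound 1 share a core and differ at one spot: hydrogen in place of methoxy on an aromatic carbon. That step gave a number 5 percentage points higher from compound 2 to compound 1 (within the scatter). Compound 3 sits at the high end of the three numbers, but all three lie within the scatter of one another, so no order among them can be read.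

Compound 4 `COc1ccc(-c2cc(/C=C/C(=O)c3cc(OC)c(OC)c(OC)c3)[nH]n2)cc1OC` has not yet been measured. It comes from compound 3 by the change (hydrogen in place of methoxy on an aromatic carbon). The surroundings differ slightly from the earlier pair: in compound 3 the site is also meta to a methoxy group, so this is the same kind of change, not the same one. How the core of compound 3 differs from that of compound 2 is not broken down here.

Because the earlier step of a number 5 percentage points higher from compound 2 to compound 1 (within the scatter) stayed within the scatter, the step from compound 3 to compound 4 is expected to be similarly small, a number 1 percentage points higher from compound 3 to compound 4 (within the scatter). Compound 4 is therefore estimated to give 96%, expected to fall between 85% and 105%.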

Compound 4, a percentage reported as activity, at one concentration (the size of the read-out at that concentration, not a potency): 86%
Compound 4: the middle estimate sits 10 percentage points above what was measured; measured number inside the range.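

In this assay hydrogen in place of methoxy on an aromatic carbon gave a number 9 percentage points lower from compound 3 to compound 4 (within the scatter) on this second core. Set side by side, the two steps do not differ by more than repeated measurements would: the same change on two cores in this assay, a number 5 percentage points higher (within the scatter) from compound 2 to compound 1 and a number 9 percentage points lower (within the scatter) from compound 3 to compound 4, 14 percentage points apart, within the scatter of two such steps. Within the data shown here, this shows no sign that the core alters the outcome of the change, but it does not show that the change carries over unaltered, since steps this small on only two cores cannot reveal a modest dependence on the core.

The compounds shown leave open what other groups at this site would give, such as a hydroxyl, a fluorine or a longer chain like ethoxy. They also leave open how these compounds behave at other concentrations.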